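The source may hold more compounds than are shown below. What is called first, only, known or untested is meant among the compounds shown, and "the series" means these compounds.

Among the measured compounds shown here, compound 2 `COc1ccc(C(=O)NCc2ccc(NS(C)(=O)=O)cc2Cl)cc1` stands lowest of the two compounds measured so far in an ADME assay on microsomes from liver (Rattus norvegicus, strain Sprague-Dawley) for metabolic stability, read by HPLC, using NADPH, with stated times of 5 min and 60 min, tested at 10 uM; on this read-out lower numbers stand for slow clearance and higher numbers for fast clearance: compound 2 gives 5 mL.min-1.g-1, while compound 1 `CC(C)S(=O)(=O)Nc1ccc(CNC(=O)c2ccc(C(C)(C)C)cc2)c(Cl)c1` gives 23 mL.min-1.g-1, a higher number and a gap beyond the usual scatter. Compound 3 `CS(=O)(=O)Nc1ccc(CNC(=O)c2ccc(C(F)(F)C(F)(F)F)cc2)c(Cl)c1` has not yet been measured. It differs from compound 2 in one place, (1,1,2,2,2-pentafluoroethyl in place of methoxy on an aromatic carbon). For the measured compounds named here, no measured step of this kind is available, so the direction rests on expectation alone: a rise in this assay, larger than the scatter but modest. Compound 3 is expected to give 12 mL.min-1.g-1, within 4 mL.min-1.g-1 to 35 mL.min-1.g-1. This estimate means an expected step of a 2.4-fold higher number from compound 2 to compound 3 (0.38 log units; beyond the scatter).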

Compound 3, intrinsic clearance in microsomes: 14 mL.min-1.g-1
Estimate against measurement, compound 3: 1.2-fold (0.07 log units) below; the measured number falls inside the stated range.
By their numbers in this assay, from the lowest: compound 2; then compounds 3 and 1 (each within the scatter of the next).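

In this assay, among the compounds shown here, the change from methoxy to 1,1,2,2,2-pentafluoroethyl gives a 2.8-fold higher number from compound 2 to compound 3 (0.45 log units; beyond the scatter) and is the first single-place step seen at this position, on an aromatic carbon para to a large group. It shows that the read-out responds to the group held here, though only modestly for this pair. Nothing available accounts for the rise.

From the compounds shown here alone, how trifluoromethyl, an amine or a carboxylic acid would read at this position remains open. So does whether the same change would give a similar step on the core of compound 1.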